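A Naphthalenyl Replacement on an Indolinone-Thiazolone Pyrazoline Series

This account rests on a few compounds, and the source may have more. Where it says the series, first, only, none or still open, it means among the compounds named here.

Compound 2 `COc1ccc(C2=NN(C3=NC(=O)/C(=C4\C(=O)Nc5ccccc54)S3)C(c3ccc(OC)cc3)C2)cc1` sits at the top of the two numbers in a functional assay on cells (Melanoma cell, Homo sapiens) for cytotoxicity, read by sulforhodamine B assay, with a stated time of 48 h (a lower number here means a stronger inhibitor of growth, a higher number a weaker inhibitor of growth), giving 100000 nM, while compound 1 `COc1ccc(C2CC(c3ccccc3)=NN2C2=NC(=O)/C(=C3\C(=O)Nc4ccccc43)S2)cc1` gives 4510 nM. Going by the values given here, the only measured step, a 22-fold higher number from compound 1 to compound 2 (1.35 log units; beyond the scatter), adds a methoxy to the aromatic ring. Compound 3 `COc1ccc(C2CC(c3ccc4ccccc4c3)=NN2C2=NC(=O)/C(=C3\C(=O)Nc4ccccc43)S2)cc1` carries the change (naphthalen-2-yl in place of 4-methoxyphenyl on a carbon with a double bond to nitrogen). Among the compounds with values here, no measured step covers this swap; the carbon-only aromatic ring of compound 1 with 4510 nM is the nearest guide. Compound 3 is therefore expected to show a large drop, a 13-fold lower number from compound 2 to compound 3 (1.10 log units; beyond the scatter), and an estimated 8000 nM with a range of 2000 nM to 40000 nM.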

Compound 3, concentration for total growth inhibition: 27000 nM
Estimate against measurement, compound 3: 3.4-fold (0.53 log units) below, and the stated range covers the measured number.
By their numbers in this assay, from the lowest: compound 1; then compound 3; then compound 2.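

Swapping 4-methoxyphenyl for naphthalen-2-yl on this carbon gives a 3.7-fold lower number from compound 2 to compound 3 (0.57 log units; beyond the scatter) in this assay and so regains only part of the loss seen with the methoxy group. Set against the phenyl group, the same naphthalen-2-yl group gives a 6.0-fold higher number from compound 1 to compound 3 (0.78 log units; beyond the scatter) and leaves compound 1 lowest of the three. Nothing available explains these differences.

Still open, on these data alone, is how an amine or a carboxylic acid on the phenyl ring would read at this position. Also open, as far as these compounds go, is whether a chlorine there would keep the number of compound 1.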